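The source may hold more compounds than are shown below. What is called first, only, known or untested is meant among the compounds shown, and "the series" means these compounds.

Compound 1 `ClCc1ccccc1Cn1cnc2c(Cl)nc(Cl)nc21` and compound 2 `ClCc1cccc(Cn2cnc3c(Cl)nc(Cl)nc32)c1` are built from the same atoms joined differently; how their two cores differ is not broken down here. In a functional assay on 786-0 cells (Homo sapiens) for cytotoxicity, read by sulforhodamine B assay, with a stated time of 48 h (on this read-out higher numbers stand for lower toxicity in this test and lower numbers for higher toxicity in this test), compound 1 gives 6450 nM, and compound 2 gives 57500 nM, the higher of the two plain numbers. Compound 3 `Nc1nc(Cl)c2ncn(Cc3ccccc3CCl)c2n1` carries an amino group where compound 1 carries a chloro group: amino in place of chloro on an aromatic carbon. In this assay compound 3 gives > 100000 nM, which is a limit of the test and not a number. The step of an at least 15-fold higher number from compound 1 to compound 3 (1.19 log units; beyond the scatter) is accordingly a large move toward lower toxicity. Compound 4 `Nc1nc(Cl)c2ncn(Cc3cccc(CCl)c3)c2n1` has not yet been measured; it stands to compound 2 as compound 3 stands to compound 1: amino in place of chloro on an aromatic carbon. The surroundings of the changed carbon read the same word for word in both pairs, so this is the same change, now made on the core of compound 2. Since compound 2 already starts from a much higher number than compound 1, a step of the size seen from compound 1 to compound 3 would carry compound 4 past (the limit of > 100000 nM in this assay, at which 1 of the 3 values shown sits). Compound 4 is therefore expected to give about 400000 nM in this assay, within a range of 100000 nM to 1500000 nM. The expected step of a 7.0-fold higher number from compound 2 to compound 4 (0.84 log units; beyond the scatter) rests on the measured step of an at least 15-fold higher number from compound 1 to compound 3 (1.19 log units; beyond the scatter) and on compound 2 giving 57500 nM. Most likely compound 4 will be reported only as a limit rather than as a number.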

Compound 4, concentration lethal to 50% of the cells: 91200 nM
Estimate against measurement, compound 4: 4.4-fold (0.64 log units) above, and the stated range ends above it.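

Made on the other core, the change of chloro to amino on an aromatic carbon gives a 1.6-fold higher number from compound 2 to compound 4 (0.20 log units; within the scatter) in this assay, so a step measured on one core in this series does not carry over at the same size to the other: the same change on two cores in this assay, an at least 15-fold higher number (1.19 log units; beyond the scatter) from compound 1 to compound 3 and a 1.6-fold higher number (0.20 log units; within the scatter) from compound 2 to compound 4, at least 9.7-fold (0.99 log units) apart, beyond the scatter of two such steps. As far as these compounds go, compound 3 gives > 100000 nM, which is a limit of the assay and not a number, so the true size of the earlier step stays unknown, although the gap between the two steps is still clear. These two pairs show that the same change can give very different steps on two closely related cores, but they do not show why the steps differ or which of them a third core would follow.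

At this aromatic carbon the compounds shown carry only chloro or amino, so it remains open how a methylamino group, a methoxy group or a hydroxyl group would read on either core. From the compounds shown here alone, it also remains open whether the gap between the two cores would persist if a longer chain or an amine took the place of the chloro group on the benzyl side chain.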